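The source may report more compounds than this note shows. Statements on the series, on what has been measured and on what is new or still open speak of the compounds shown alone.

Measured so far:
Compound 1, `COc1cccc(C(O)CCn2nc3c(Br)c(Br)c(Br)c(Br)c3n2)c1`: 121%
Compound 2, `C[C@@H](O)CCn1nc2c(Br)c(Br)c(Br)c(Br)c2n1`: 109%

Both compounds share the same core and differ in the chain carrying the hydroxyl. In a functional assay on MCF7 cells (Homo sapiens) for antiproliferative activity, read by MTT assay, with a stated time of 24 h, tested at 12.5 uM (a lower number here means a stronger effect, a higher number a weaker effect of the compound at the concentration tested), compound 1 gives 121%, the higher of the two numbers shown; compound 2 gives 109%, lower by a margin beyond the usual scatter. Neither number points to a reduction in cell viability at the concentration tested: the read-out for both lies above the untreated level, so the series as seen here shows no antiproliferative effect.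

Compound 3, `OC(CCn1nc2c(Br)c(Br)c(Br)c(Br)c2n1)c1ccccc1`, has not yet been run in this assay. It differs from compound 1 by hydrogen in place of methoxy on an aromatic carbon; cut one bond further out, the same change reads 3-methoxyphenyl to phenyl. Among the measured compounds shown here, no step between two measured compounds of this kind is available to anchor the size of the effect. Given that compound 1 sits at 121% and compound 2 at 109%, the expectation for compound 3 is a step of a number 8 percentage points lower from compound 1 to compound 3 (within the scatter), downward if anything, but not beyond the scatter. Compound 3 is estimated at 113%, in the range 96% to 130%.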

Compound 3, a percentage reported as activity, at one concentration (the size of the read-out at that concentration, not a potency): 115%
The estimate for compound 3 lay 2 percentage points below the measured number; the measured number falls inside the stated range.
By their numbers in this assay, from the lowest: compounds 2, 3 and 1 (each within the scatter of the next, the first and the last beyond it).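

Among the compounds shown here, replacing methoxy with hydrogen on an aromatic carbon, the change from 3-methoxyphenyl to phenyl, gives the first step that can be read in one place: in this assay there is a number 6 percentage points lower from compound 1 to compound 3 (within the scatter). At this position, then, the methoxy group can be lost without the read-out moving beyond the usual scatter, which the gap between the two earlier compounds, differing in more than one place, could not show. With the methoxy group gone, compound 3 at 115% still shows no sign of reduced cell viability at the concentration tested, so the unsubstituted phenyl does not bring out an antiproliferative effect in this series.

This single step covers only hydrogen and methoxy on that aromatic carbon, and it leaves open whether a different group there, such as an amine, a carboxylic acid or a longer alkoxy chain, would move the read-out beyond the scatter or bring it down to a real effect. No measured property bears on this step.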